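Shortening the Hydroxamic Chain of Compound 1

The source may report more compounds than this note shows. Statements on the series, on what has been measured and on what is new or still open speak of the compounds shown alone.

Measured in a functional assay on Hep 3B2 cells (Homo sapiens) for antiproliferative activity, read by sulforhodamine B assay, with a stated time of 48 h; on this read-out lower numbers stand for stronger inhibition of growth and higher numbers for weaker inhibition of growth:
- compound 1 `CC(C)CCc1c(OCCCCCCC(=O)NO)ccc2c1OC(=O)CC2`: > 30000 nM
- compound 2 `CC(C)CCc1c(OCCCCC(=O)NO)ccc2ccc(=O)oc12`: 1310 nM
- compound 3 `CC(C)CCc1c(OCCCCCCC(=O)NO)ccc2ccc(=O)oc12`: 750 nM

Compound 1 has only a limit, > 30000 nM, and no exact number. Compound 4 `CC(C)CCc1c(OCCCCC(=O)NO)ccc2c1OC(=O)CC2` differs from it in one place: hydroxycarbamoyl in place of 2-(hydroxycarbamoyl)ethyl on a saturated chain carbon, four bonds along the chain from an oxygen on an aromatic ring. Hydroxycarbamoyl replaces 2-(hydroxycarbamoyl)ethyl on a saturated chain carbon, four bonds along the chain from an oxygen on an aromatic ring. Within the data shown here, the only measured step that bears on this is the same swap run in reverse on the different core of compound 2 and compound 3, namely a 1.7-fold lower number from compound 2 to compound 3 (0.24 log units; within the scatter). No step beyond the scatter is therefore expected in this assay. The expected change is a number no higher from compound 1 to compound 4 (the limit leaves the size open). For compound 4 the estimated value is 30000 nM, with an expected range from 10000 nM to 60000 nM.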

Compound 4, concentration for 50% growth inhibition: > 30000 nM
Compound 4: no number, only a limit (the forecaster's own chance of this, stated with the estimate: 70%); the middle value lies on the limit itself.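

Among these compounds, compound 1 and compound 4 each give only a limit, so no step between them can be read. On these data alone, whether hydroxycarbamoyl in place of 2-(hydroxycarbamoyl)ethyl changes growth inhibition at all on this core stays open.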